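Ester to Primary Amide: Expected Potency of Compound 3

The source may report more compounds than this note shows. Statements on the series, on what has been measured and on what is new or still open speak of the compounds shown alone.

Measured compounds:
Compound 1, `Cc1ccc(-c2cnc(C(=O)CCCCCCc3ccccc3)o2)nc1`, in an assay (Rattus norvegicus) for inhibition of Fatty-acid amide hydrolase 1 (Homo sapiens) (on this read-out lower numbers stand for stronger inhibition and higher numbers for weaker inhibition), compound 1 gives 2.8 nM.
Compound 2, `COC(=O)c1ccc(-c2cnc(C(=O)CCCCCCc3ccccc3)o2)nc1`, in this assay compound 2 gives 3.5 nM.

Compounds 1 and 2 share the same core and differ only in the group on an aromatic carbon; the step of a 1.3-fold higher number from compound 1 to compound 2 (0.10 log units; within the scatter) shows that the two values lie within the scatter of each other, so neither can be called the stronger inhibitor. Compound 2 is the starting point for the next change. Compound 3, `NC(=O)c1ccc(-c2cnc(C(=O)CCCCCCc3ccccc3)o2)nc1`, arises from compound 2 by amino in place of methoxy on a carbonyl carbon. Among the measured compounds shown here, only one step has been measured so far, and it sits on an aromatic carbon rather than on the carbonyl carbon; it does not bear directly on the present change and was itself within the scatter. There is therefore no measured basis for expecting a shift in this assay beyond the scatter, in either direction. Compound 3 is accordingly expected to give about 4 nM, within a range of 1.5 nM to 12 nM. The expected step of a 1.1-fold higher number from compound 2 to compound 3 (0.06 log units; within the scatter) is estimated to stay within the usual scatter.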

Compound 3, inhibition constant: 1.2 nM
Compound 3: the middle estimate sits 3.3-fold (0.52 log units) above what was measured, and the stated range ends above it.
By their numbers in this assay, from the lowest: compound 3; then compounds 1 and 2 (each within the scatter of the next).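

Among the compounds shown here, putting amino in place of methoxy on this carbonyl carbon gives a 2.9-fold lower number from compound 2 to compound 3 (0.46 log units; beyond the scatter) in this assay and is the first step to pass beyond the scatter. The group on this aromatic carbon therefore matters to the read-out, which the methyl and methoxycarbonyl pair alone did not show: carbamoyl in place of methyl gives a 2.3-fold lower number from compound 1 to compound 3 (0.37 log units; beyond the scatter) and leaves compound 3 with the lowest number of the three, while compounds 1 and 2 stay within the scatter of each other. Both steps are modest, and no measurement in hand accounts for the difference between carbamoyl and methoxycarbonyl.

The compounds shown leave open whether this effect needs the unsubstituted amino group or would persist with methylamino or dimethylamino on the same carbonyl carbon, and how a carboxylic acid or a nitrile on the aromatic carbon would compare. They also leave open whether the step would be of the same size with a shorter chain on the shared core.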